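The compounds below may be only part of what the source reports. "The series", "measured", "known", "first", "only" and "open" are said of these compounds alone.

Measured compounds:
Compound 1, `Cc1ccc(S(=O)(=O)N(C)C(=O)NC(C)c2cc(Br)ccc2OC(C)C)cc1`: in a functional assay on thoracic aorta (Rattus norvegicus, strain Wistar), with a stated time of 15 min (on this read-out higher numbers stand for an effect only at larger amounts of compound and lower numbers for an effect already at smaller amounts), compound 1 gives 34700 nM.
Compound 2, `CCOc1ccc(F)cc1C(C)NC(=O)N(C)S(=O)(=O)c1ccccc1`: in this assay compound 2 gives 11500 nM.
Compound 3, `CC(C)Oc1ccc(Br)cc1C(C)NC(=O)NS(=O)(=O)c1ccccc1`: in this assay compound 3 gives 143000 nM.

Compound 2 holds the lowest of the three numbers in this assay, with compound 1 next and compound 3 furthest, both separated from it by more than the usual scatter. For the measured compounds named here, no pair among the measured compounds differs in a single place, so no isolated step can be read from these three.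

The next compound, compound 4, `CCOc1ccc(F)cc1C(C)NC(=O)N(C)S(=O)(=O)c1ccc(C)cc1`, is derived from compound 2 by one change: methyl in place of hydrogen on an aromatic carbon. Compound 1 also carries a methyl on that ring, but it differs from compound 2 in several further places, so its number cannot be set against compound 2 as a clean comparison.

Given no single-change step among the measured compounds, the step of a 1.0-fold higher number from compound 2 to compound 4 (0.02 log units; within the scatter) is expected to be small, in either direction, and most likely within the scatter. Compound 4 is therefore expected to give about 12000 nM in this assay, within 4000 nM to 40000 nM.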

Compound 4, half-maximal effective concentration: 7800 nM
The estimate for compound 4 lay 1.5-fold (0.19 log units) above the measured number; the range from low to high includes it.
By their numbers in this assay, from the lowest: compounds 4 and 2 (each within the scatter of the next); then compound 1; then compound 3.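

For the compounds shown here, the first comparison that isolates a single place concerns phenyl to 4-methylphenyl: in this assay, the methyl gives a 1.5-fold lower number from compound 2 to compound 4 (0.17 log units; within the scatter). Going by these compounds alone, on this aromatic carbon, para to a large group, a methyl in place of hydrogen therefore leaves the number of this pair inside the usual scatter, which the earlier compounds, all differing in several places, could not show. No measurement is at hand that explains this result.

From the compounds shown here alone, whether an amine, a carboxylic acid or a longer chain on this carbon would move the number beyond the scatter remains open. Also open, going by these compounds, is the size of single steps elsewhere, such as ethoxy to isopropoxy or fluorine to bromine, since compound 1 differs from compound 4 in more than one place.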